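This account rests on a few compounds, and the source may have more. Where it says the series, first, only, none or still open, it means among the compounds named here.

Working notes on the series, all read in a functional assay on A-375 cells (Homo sapiens) for antiproliferative activity, read by MTT assay, with a stated time of 24 h; on this read-out lower numbers stand for stronger inhibition and higher numbers for weaker inhibition. Compound 1 `COc1cc(OC)c(-c2coc3cc(OCC(=O)c4cccc(C(F)(F)F)c4)ccc3c2=O)cc1OC` gives > 10000 nM, which is a limit of the assay and not a number. Compound 2 `COc1cc(OC)c(-c2coc3cc(OCc4cccc(F)c4)ccc3c2=O)cc1OC` gives 1300 nM, and compound 3 `COc1cc(OC)c(-c2coc3cc(OCc4ccccc4Br)ccc3c2=O)cc1OC` gives 2850 nM. Compound 3 is therefore the higher of the two true numbers, and the gap is small but beyond the scatter: a 2.2-fold higher number from compound 2 to compound 3 (0.34 log units; beyond the scatter).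

Next is compound 4 `COc1cc(OC)c(-c2coc3cc(OCc4cccc(C(F)(F)F)c4)ccc3c2=O)cc1OC`. The change is 3-(trifluoromethyl)phenyl in place of 2-bromophenyl on a saturated chain carbon bound to an oxygen on an aromatic ring.

Two kinds of step bear on this. Compound 1 carries a carbonyl that compounds 2, 3 and 4 lack, and removing it with the swap of ring gave an at least 7.6-fold lower number from compound 1 to compound 2 (0.88 log units; beyond the scatter) and an at least 3.5-fold lower number from compound 1 to compound 3 (0.54 log units; beyond the scatter). Compound 4 is therefore expected to lie near compounds 2 and 3, not at the limit. The closest guide is the modest 2.2-fold higher number from compound 2 to compound 3 (0.34 log units; beyond the scatter), where 3-fluorophenyl, substituted like the entering group, sits at the lower number. A small move towards compound 2 is thus expected in this assay, probably not beyond the scatter. The expected step is a 1.5-fold lower number from compound 3 to compound 4 (0.18 log units; within the scatter). For compound 4 the estimate is 1900 nM, with an expected range of 750 nM to 5000 nM.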

Compound 4, half-maximal inhibitory concentration: 1140 nM
Beside the measured number, compound 4's estimate is 1.7-fold (0.22 log units) above it; the measured number falls inside the stated range.
By their numbers in this assay, from the lowest: compounds 4 and 2 (each within the scatter of the next); then compound 3. At a limit, above all of these: compound 1.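

In this assay, the move to 3-(trifluoromethyl)phenyl on a saturated chain carbon bound to an oxygen on an aromatic ring gives a 2.5-fold lower number from compound 3 to compound 4 (0.40 log units; beyond the scatter), while trifluoromethyl in place of fluoro on an aromatic carbon gives a 1.1-fold lower number from compound 2 to compound 4 (0.06 log units; within the scatter), so the 3-fluorophenyl and 3-(trifluoromethyl)phenyl groups cannot be told apart on this read-out and compound 3 alone stands higher among the three true numbers. Among these compounds, with 3-(trifluoromethyl)phenyl on both sides, an at least 8.7-fold lower number from compound 1 to compound 4 (0.94 log units; beyond the scatter) reads the chain carbonyl on its own for the first time, as this is the one pair involving compound 1 in which the ring stays unchanged. The size of that step is only a bound, because the value of compound 1 is a limit of the assay and not a number: the limit of > 10000 nM in this assay, at which 1 of the 4 values shown sits.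

Compound 3 differs from compounds 2 and 4 in both its substituent and where that substituent sits, so a 3-bromophenyl group would be needed to separate these two changes. Going by these compounds, whether any ring substituent matters at all also stays open, and a plain phenyl, a ring carrying a methoxy group or an amine, or a longer chain in place of the single chain carbon would test this.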